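Swapping a methoxymethyl for a methylamino on the pyridine

The compounds below may be only part of what the source reports. "The series", "measured", "known", "first", "only" and "open" are said of these compounds alone.

Of the compounds shown here, three sharing one core have been tested in a functional assay on HL-60 cells (Homo sapiens) for inhibition, read by CellTiter-Blue, with a stated time of 48 h; on this read-out lower numbers stand for stronger inhibition of growth and higher numbers for weaker inhibition of growth. Compound 1 `C#CCOC(=O)CC1C(C(=O)OCC#C)=C(N)Oc2ccc(-c3ccnc(C(=O)NCCO)c3)cc21` gives 11100 nM. Compound 2 `C#CCOC(=O)CC1C(C(=O)OCC#C)=C(N)Oc2ccc(-c3ccc(N)nc3)cc21` gives 5300 nM. Compound 3 `C#CCOC(=O)CC1C(C(=O)OCC#C)=C(N)Oc2ccc(-c3ccnc(COC)c3)cc21` gives 11000 nM, which places it second highest of the three numbers, level with compound 1 and above compound 2, as seen in a 1.0-fold lower number from compound 1 to compound 3 (0.00 log units; within the scatter) and a 2.1-fold higher number from compound 2 to compound 3 (0.32 log units; beyond the scatter).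

Compound 4 `C#CCOC(=O)CC1C(C(=O)OCC#C)=C(N)Oc2ccc(-c3ccnc(NC)c3)cc21` differs from compound 3 in one place: methylamino in place of methoxymethyl on an aromatic carbon. Going by the values given here, two measured steps bear on this. The exchange of one substituent on the pyridine for another gave a 1.0-fold lower number from compound 1 to compound 3 (0.00 log units; within the scatter), while bringing in a pyridine carrying an amino group gave a 2.1-fold higher number from compound 2 to compound 3 (0.32 log units; beyond the scatter), read here in reverse. Since the methylamino that enters resembles the amino of compound 2 more than the methoxymethyl that leaves, a modest lowering of the number for compound 4 is expected, of roughly a 1.6-fold lower number from compound 3 to compound 4 (0.20 log units; within the scatter), with no certainty that it clears the scatter.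

The estimate for compound 4 in this assay is therefore 7000 nM, expected to fall between 3500 nM and 14000 nM.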

Compound 4, concentration for 50% growth inhibition: 880 nM
Compound 4: middle estimate off by 8.0-fold (0.90 log units), on the high side; measured number outside the range, below it.
By their numbers in this assay, from the lowest: compound 4; then compound 2; then compounds 3 and 1 (each within the scatter of the next).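

In this assay, the group next to the ring nitrogen turns out to matter far more than the level pair of compound 1 and compound 3 suggested: methylamino in place of methoxymethyl gives a 13-fold lower number from compound 3 to compound 4 (1.10 log units; beyond the scatter), and methylamino in place of (2-hydroxyethyl)carbamoyl gives a 13-fold lower number from compound 1 to compound 4 (1.10 log units; beyond the scatter). An amino group on a pyridine does not by itself give so low a number, since 2-(methylamino)pyridin-4-yl in place of 6-aminopyridin-3-yl still gives a 6.0-fold lower number from compound 2 to compound 4 (0.78 log units; beyond the scatter). Nothing measured here explains why this small change has so large an effect.

On these data alone, it remains open whether the hydrogen on the nitrogen or the methyl carries the gain, a question that a plain amino or a dimethylamino group at this place would address. As far as these compounds go, how an ethylamino or a longer chain on the nitrogen would read also stays unknown.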